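From 2-fluorophenyl to 2-methylphenyl in a cytotoxicity assay

The source may hold more compounds than are shown below. What is called first, only, known or untested is meant among the compounds shown, and "the series" means these compounds.

In an ADME assay on MT4 cells (Homo sapiens) for cytotoxicity, read by MTT assay, with a stated time of 96 h (a lower number here means that less compound is tolerated, a higher number that more compound is tolerated), compound 1 `NS(=O)(=O)c1ccc(N2N=C(c3ccccc3)CC2c2ccccc2F)cc1` gives 42000 nM and compound 3 `NS(=O)(=O)c1ccc(N2N=C(c3ccc(OCc4ccccc4)cc3)CC2c2ccccc2F)cc1` gives 39000 nM so the two lie within the scatter of each other. Compound 2 `NS(=O)(=O)c1ccc(N2N=C(c3ccc(OCc4ccccc4)cc3)CC2c2ccc(F)cc2)cc1` gives > 100000 nM which is a limit of the assay and not a number. Compound 4 `Cc1ccccc1C1CC(c2ccccc2)=NN1c1ccc(S(N)(=O)=O)cc1` differs from compound 1 by methyl in place of fluoro on an aromatic carbon with methyl in place of fluoro on an aromatic carbon. Among the compounds with values here, no measured step makes this swap. Benzyloxy in place of hydrogen gave a 1.1-fold lower number from compound 1 to compound 3 (0.03 log units; within the scatter) while 2-fluorophenyl in place of 4-fluorophenyl gave an at least 2.5-fold lower number from compound 2 to compound 3 (0.40 log units; beyond the scatter) so a change on that ring can move the number. No direction can be read from these two steps, so the estimated step is a 1.1-fold higher number from compound 1 to compound 4 (0.03 log units; within the scatter) and is expected to stay within the scatter. For compound 4 the expected value is 45000 nM with an estimated range from 20000 nM to 100000 nM around it.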

Compound 4, half-maximal cytotoxic concentration: 43000 nM
The estimate for compound 4 lay 1.0-fold (0.02 log units) above the measured number; the measured number falls inside the stated range.
By their numbers in this assay, from the lowest: compounds 3, 1 and 4 (each within the scatter of the next). At a limit, above all of these: compound 2.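

Methyl in place of fluoro, on an aromatic carbon ortho to a large group, gives a 1.0-fold higher number from compound 1 to compound 4 (0.01 log units; within the scatter) in this assay. This is the first step shown that replaces the group at this position while leaving it in the same place, and the two groups cannot be told apart here. Nothing measured here bears on why the number holds.

From the compounds shown here alone, what an amine, a carboxylic acid or a longer chain would do at this position stays open. So does whether the same swap would hold in compound 3, which carries benzyloxy.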